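A longer chain on a shared core

The compounds below may be only part of what the source reports. "The series", "measured", "known", "first", "only" and "open" are said of these compounds alone.

In an ADME assay on Vero cells (Chlorocebus sabaeus) for cytotoxicity, read by reporter gene assay, with a stated time of 4 days (a higher number here means a weaker inhibitor, a lower number a stronger inhibitor), compound 1 (`CCCCCC(=O)OCC(C)(C)CC1=C(O)C(=O)c2ccccc2C1=O`) gives 169000 nM. Compound 2 (`CCCCCCCC(=O)OCC(C)(C)CC1=C(O)C(=O)c2ccccc2C1=O`) shows > 258000 nM, which is a limit of the assay and not a number. Compound 3 (`CCCCCCCCCCC(=O)OCC(C)(C)CC1=C(O)C(=O)c2ccccc2C1=O`) shows > 233000 nM, which is again only a limit. Compound 4 (`CCCCCCCCCCCCCCCCCC(=O)OCC(C)(C)CC1=C(O)C(=O)c2ccccc2C1=O`) extends the same chain: heptyl in place of hydrogen on a saturated chain carbon, ten or more bonds along the chain from a carbonyl carbon. Two earlier chain extensions bear on this change: an at least 1.5-fold higher number from compound 1 to compound 2 (0.18 log units; that floor lies within the scatter) and an at least 1.3-fold higher number from compound 1 to compound 3 (0.13 log units; that floor lies within the scatter). There is also a step that the two limits leave unreadable from compound 2 to compound 3. No step beyond the scatter is therefore expected, and another limit is likely. The expected change is an at least 1.2-fold lower number from compound 3 to compound 4 (0.08 log units; that floor lies within the scatter). Compound 4 is estimated at 190000 nM, with an expected range of 100000 nM to 300000 nM.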

Compound 4, half-maximal inhibitory concentration: 15500 nM
The estimate for compound 4 lay 12-fold (1.09 log units) above the measured number; the measured number lies below the stated range.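

Chain length at this position does move the number in this assay: the added heptyl gives the first steps beyond the scatter, with an at least 15-fold lower number from compound 3 to compound 4 (1.17 log units; beyond the scatter), an at least 16-fold lower number from compound 2 to compound 4 (1.22 log units; beyond the scatter) and an 11-fold lower number from compound 1 to compound 4 (1.04 log units; beyond the scatter). Compound 3 holds only a limit of the assay, not a number: the limit of > 233000 nM in this assay, at which 1 of the 4 values shown sits. Compound 2 likewise holds only a limit: the limit of > 258000 nM in this assay, at which 1 of the 4 values shown sits.

Which chain length, from that of compound 3 up to that of compound 4, first brings the drop stays open. So does what a longer chain, or a carboxylic acid in place of the heptyl, would do.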